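Aryl sulfide to aryl ether: one step, one estimate

The source may report more compounds than this note shows. Statements on the series, on what has been measured and on what is new or still open speak of the compounds shown alone.

Measured so far:
compound 1, `COc1ccc(Sc2nc3cc(N)cc(N)c3nc2-c2ccccc2)cc1`; in a functional assay on SF-295 cells (Homo sapiens) for inhibition, read by sulforhodamine B assay, with a stated time of 48 h (a higher number here means a weaker inhibitor of growth, a lower number a stronger inhibitor of growth), compound 1 gives < 100000 nM, which is a limit of the assay rather than a number.
compound 2, `Nc1cc(N)c2nc(-c3ccccc3)c(Sc3ccc(Cl)c(Cl)c3)nc2c1`; in this assay compound 2 gives 60300 nM.

Going by the values given here, compound 2 holds the only number in this assay; the one other value is a limit, as the limit of < 100000 nM in this assay, at which 1 of the 2 values shown sits, records. The step that the limit leaves unreadable from compound 1 to compound 2 therefore has no readable size. Compound 3, `Nc1cc(N)c2nc(-c3ccccc3)c(Oc3ccc(F)cc3)nc2c1`, differs from compound 2 in one place: 4-fluorophenoxy in place of (3,4-dichlorophenyl)sulfanyl on an aromatic carbon. Among the compounds with values here, no measured step covers this change; the single step from compound 1 to compound 2 swaps one aryl group on a sulfur for another and is unreadable, so it offers no size to carry over. The expectation for compound 3 thus rests on compound 2 alone, with a wide spread on either side, and a change beyond the scatter in either direction cannot be ruled out. Compound 3 is estimated at 50000 nM, ranging from 15000 nM to 100000 nM. The step this expects, a 1.2-fold lower number from compound 2 to compound 3 (0.08 log units; within the scatter), is expected to stay within the scatter.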

Compound 3, concentration for total growth inhibition: 38900 nM
Compound 3: the middle estimate sits 1.3-fold (0.11 log units) above what was measured; the range from low to high includes it.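

At the aromatic carbon next to the ring nitrogen, 4-fluorophenoxy in place of (3,4-dichlorophenyl)sulfanyl gives, in this assay, a 1.6-fold lower number from compound 2 to compound 3 (0.19 log units; within the scatter). Going by these compounds alone, this is the first readable step, and it shows that the linking sulfur and the aryl group can be exchanged together at this position without a change beyond the scatter, although this single step does not separate the two exchanges. Compound 1 stands at a limit, so the steps that start from it cannot be read: the limit of < 100000 nM in this assay, at which 1 of the 3 values shown sits.

On these data alone, the effect of exchanging sulfur for oxygen with the aryl group held fixed remains open. So does the response of this position to a group of another kind, such as an amine or a longer alkyl chain.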